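Adding a dimethylamino group to compound 1

The source may report more compounds than this note shows. Statements on the series, on what has been measured and on what is new or still open speak of the compounds shown alone.

Among the compounds with values here, in a functional assay on MOLT-4 cells (Homo sapiens) for antiproliferative activity, with a stated time of 48 h (a lower number here means a stronger inhibitor, a higher number a weaker inhibitor), compound 1 `C=C(Br)C(=O)Nc1ccc(C(=O)/C=C/c2ccccc2)cc1` gives 500 nM, the higher of the two numbers measured so far. Compound 2 `C=C(Br)C(=O)Nc1ccc(C(=O)/C=C/c2ccccc2OC)cc1` gives 240 nM. The untested compound 3 `C=C(Br)C(=O)Nc1ccc(C(=O)/C=C/c2ccc(N(C)C)cc2)cc1` keeps the core of compound 1 and changes it in one place: dimethylamino in place of hydrogen on an aromatic carbon. In words, this is dimethylamino in place of hydrogen on an aromatic carbon. Within the data shown here, only one measured step bears on this change: methoxy in place of hydrogen on an aromatic carbon gave a 2.1-fold lower number from compound 1 to compound 2 (0.32 log units; beyond the scatter). That step involves a different group and is a single example, so it is only a loose guide. A modest move toward a lower number is therefore expected, although a result within the scatter would be no surprise. The expected step is a 2.0-fold lower number from compound 1 to compound 3 (0.30 log units; within the scatter). For compound 3 the estimated value is 250 nM, with an expected range from 90 nM to 700 nM.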

Compound 3, half-maximal inhibitory concentration: 1300 nM
For compound 3 the middle estimate is 5.2-fold (0.72 log units) below the measured one, outside the stated range (above it).
By their numbers in this assay, from the lowest: compound 2; then compound 1; then compound 3.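

In this assay, dimethylamino in place of hydrogen on an aromatic carbon, para to a large group, gives a 2.6-fold higher number from compound 1 to compound 3 (0.41 log units; beyond the scatter) and so makes the compound a weaker inhibitor than compound 1. The earlier step, a 2.1-fold lower number from compound 1 to compound 2 (0.32 log units; beyond the scatter), ran the opposite way, which shows that replacing an aromatic hydrogen on the core of compound 1 does not always lower the number. Nothing measured here accounts for why these two changes differ in direction.

The compounds shown leave open whether the higher number belongs to dimethylamino itself or would follow any group placed para to the large group. A plain amino group or a carboxylic acid at that same aromatic carbon would help separate these two readings.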